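From Cyclopropyl to Ethyl on the Amide Nitrogen

The source may report more compounds than this note shows. Statements on the series, on what has been measured and on what is new or still open speak of the compounds shown alone.

- compound 1 `COc1cc(Cl)c(-c2nc(SCC(=O)NC3CC3)nc3[nH]cc(C#N)c23)cc1OC` gives 69 nM
- compound 2 `COc1cc(Cl)c(-c2nc(SCC(=O)NC3CC3)nc3[nH]cc(C#N)c23)cc1O` gives 102 nM
- compound 3 `CCOc1cc(-c2nc(SCC(=O)NC3CC3)nc3[nH]cc(C#N)c23)c(Cl)cc1OC` gives 25 nM

In a functional assay on BT-474 cells (Homo sapiens) for antiproliferative activity, read by sulforhodamine B assay, with a stated time of 4 days (on this read-out lower numbers stand for stronger inhibition of growth and higher numbers for weaker inhibition of growth), compound 3 has the lowest number of the three. Compound 4 `CCNC(=O)CSc1nc(-c2cc(OCC)c(OC)cc2Cl)c2c(C#N)c[nH]c2n1` carries ethyl in place of cyclopropyl on an amide-type nitrogen. Among the measured compounds shown here, no measured step touches that group. All three concern an oxygen on an aromatic ring: a 1.5-fold higher number from compound 1 to compound 2 (0.17 log units; within the scatter) stayed within the scatter, while a 2.8-fold lower number from compound 1 to compound 3 (0.44 log units; beyond the scatter) and a 4.1-fold lower number from compound 2 to compound 3 (0.61 log units; beyond the scatter) were modest. They therefore give only a rough sense of scale. A small expected rise, not clearly beyond the scatter, is the cautious reading (a 1.4-fold higher number from compound 3 to compound 4 (0.15 log units; within the scatter)). In this assay the estimate for compound 4 is 35 nM with an expected range (12 nM to 100 nM).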

Compound 4, concentration for 50% growth inhibition: 44 nM
Compound 4: the middle estimate sits 1.3-fold (0.10 log units) below what was measured; the range from low to high includes it.
By their numbers in this assay, from the lowest: compounds 3, 4, 1 and 2 (each within the scatter of the next, the first and the last beyond it).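

In this assay, among the compounds shown here, the first change at the amide-type nitrogen, ethyl in place of cyclopropyl, gives a 1.8-fold higher number from compound 3 to compound 4 (0.25 log units; within the scatter). At this position, then, the three-membered ring can be given up for an open ethyl group without a change that stands out from the scatter. No measurement to hand bears on why the two groups read alike.

Still open, as far as these compounds go, is how a longer chain such as propyl, or a chain carrying an amine, would read on this nitrogen. Also open, from the compounds shown here alone, is whether ethyl and cyclopropyl would read alike on the rest of compound 1 or compound 2.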